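Cytotoxicity Step from Compound 2 to Compound 3

The source may report more compounds than this note shows. Statements on the series, on what has been measured and on what is new or still open speak of the compounds shown alone.

Compound 1 `COC(=O)c1ccc(NCc2cncn2Cc2ccccc2)cc1-c1ccccc1`: > 1000 nM
Compound 2 `c1ccc(-c2ccc(Cn3cncc3CNc3cccc(-c4ccccc4)c3)cc2)cc1`: 10000 nM

Of the compounds shown here, two have so far been measured in a toxicity assay on NIH3T3 cells (Mus musculus) for cytotoxicity, read by resazurin assay; a lower number here means that less compound is needed, a higher number that more compound is needed for the effect. Compound 1 gives only a limit there, > 1000 nM, as the limit of > 1000 nM in this assay, at which 1 of the 2 values shown sits. Going by the values given here, compound 2 gives 10000 nM, the single full number in this assay. Compound 3 `O=C(OC1CCCCC1)c1ccc(NCc2cncn2Cc2ccc(-c3ccccc3)cc2)cc1-c1ccccc1` has not yet been measured; it differs from compound 2 by cyclohexyloxycarbonyl in place of hydrogen on an aromatic carbon. Among the compounds with values here, no measured pair shows what such a change does in this assay. The step of a 2.0-fold lower number from compound 2 to compound 3 (0.30 log units; within the scatter) is expected to be small, toward a lower number but hardly beyond the scatter. Compound 3 is therefore estimated at 5000 nM, within the range 2000 nM to 15000 nM.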

Compound 3, half-maximal effective concentration: > 10000 nM
Compound 3: no number, only a limit (the forecaster's own chance of this, stated with the estimate: 30%); middle value at least 2.0-fold (0.30 log units) from the limit.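

In this assay, cyclohexyloxycarbonyl on an aromatic carbon, ortho to a phenyl group and para to a large group, gives a number no lower from compound 2 to compound 3 (the limit leaves the size open). Going by these compounds alone, this is the first sign that a group this large at this position does not lower the number, though the reading rests on a limit: the limit of > 10000 nM in this assay, at which 1 of the 3 values shown sits. On these data alone, how far the number rises stays open. So does what a carboxylic acid or an amine at the same position would do in this assay.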